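Bromo to Pentyl on the Aryl Ring of a Triazole Lactone

A few compounds are considered here, and "the series" means these few. Any claim that something is new, unique, unknown or untested is made for them only; others in the source may bear on it.

Measured so far:
compound 1, `O=C1O/C(=C\Cn2cc(-c3ccc(Br)cc3)nn2)C(OCc2ccccc2)=C1OCc1ccccc1`: > 100000 nM
compound 2, `O=C1O[C@H]([C@@H](O)Cn2cc(-c3ccc(Br)cc3)nn2)C(OCc2ccccc2)=C1OCc1ccccc1`: 750 nM
compound 3, `O=C1O[C@H]([C@@H](O)Cn2cc(-c3cc(C(F)(F)F)cc(C(F)(F)F)c3)nn2)C(OCc2ccccc2)=C1OCc1ccccc1`: 28900 nM

All three compounds were tested in a functional assay on A549 cells (Homo sapiens) for antiproliferative activity, read by MTT assay, with a stated time of 72 h; a higher number here means a weaker inhibitor, a lower number a stronger inhibitor. Compound 1 gives > 100000 nM, which is a limit of the assay rather than a number. Among the two numbers that are available, compound 2 stands lowest with 750 nM. Compound 3, which carries a bis(trifluoromethyl)phenyl group instead of the bromophenyl group, gives 28900 nM, a gap to compound 2 that lies well beyond the usual scatter of repeated measurements.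

The compound still to be measured is compound 4, `CCCCCc1ccc(-c2cn(C[C@H](O)[C@H]3OC(=O)C(OCc4ccccc4)=C3OCc3ccccc3)nn2)cc1`. It differs from compound 2 in one place: pentyl in place of bromo on an aromatic carbon. Going by the values given here, no measured pair of compounds shows a swap of this kind, so the direction of the change has to be inferred from the two numbers alone. Because compound 3 sits at 28900 nM, a change on this ring can cost a great deal of potency, and a moderate loss seems more likely than a gain. The expected step from compound 2 to compound 4 is a 4.0-fold higher number from compound 2 to compound 4 (0.60 log units; beyond the scatter). Compound 4 is therefore estimated at 3000 nM, with a range from 500 nM to 20000 nM.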

Compound 4, half-maximal inhibitory concentration: 6220 nM
The estimate for compound 4 lay 2.1-fold (0.32 log units) below the measured number; measured number inside the range.
By their numbers in this assay, from the lowest: compound 2; then compound 4; then compound 3. At a limit, above all of these: compound 1.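

In this assay, swapping the bromo group for a pentyl group on the aromatic ring, with everything else in the molecule unchanged, gives an 8.3-fold higher number from compound 2 to compound 4 (0.92 log units; beyond the scatter), a loss of potency that can be pinned on this one change. Going by these compounds alone, this is the first direct comparison at this position, and it shows that the position is sensitive to what sits there: moving from 4-bromophenyl to 4-pentylphenyl, which adds heavy atoms but no ring, no hydrogen-bond donor or acceptor and no charge, is enough to produce a clear shift. The position still accepts a long chain, however, since compound 4 gives a real number of 6220 nM, so the pentyl group weakens the activity without abolishing it.

Going by these compounds, it remains open whether a shorter chain such as methyl or ethyl, or an amine or a carboxylic acid at this same place, would come closer to compound 2 or fall further away. Nothing measured here accounts for the size of this step.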